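The source may report more compounds than this note shows. Statements on the series, on what has been measured and on what is new or still open speak of the compounds shown alone.

Compound 1 `CCNc1cc(Oc2c(OC)cc3cc(C#N)ccc3c2OC)nc(Nc2ccc(C#N)cc2)n1`: in an ADME assay on MT4 cells (Homo sapiens) for cytotoxicity, read by MTT assay, with a stated time of 5 days (on this read-out higher numbers stand for lower toxicity in this test and lower numbers for higher toxicity in this test), compound 1 gives > 125000 nM, which is a limit of the assay rather than a number.
Compound 2 `CCCCNc1cc(Oc2c(OC)cc3cc(C#N)ccc3c2OC)nc(Nc2ccc(C#N)cc2)n1`: in this assay compound 2 gives > 125000 nM, again a limit.
Compound 3 `CCC(C)Nc1cc(Oc2c(OC)cc3cc(C#N)ccc3c2OC)nc(Nc2ccc(C#N)cc2)n1`: in this assay compound 3 gives > 125000 nM, also a limit.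

The account follows the step from compound 2 to compound 4 `CCCCCC(C)Nc1cc(Oc2c(OC)cc3cc(C#N)ccc3c2OC)nc(Nc2ccc(C#N)cc2)n1`, which has yet to be measured. Compound 2 stands where every compound here stands: at the limit of > 125000 nM in this assay, at which 3 of the 3 values shown sit, so it cannot be placed relative to the others. The change is 1-methylhexyl in place of butyl on a nitrogen on an aromatic ring. The measured steps that touch the same nitrogen are a step that the two limits leave unreadable from compound 1 to compound 2, a step that the two limits leave unreadable from compound 1 to compound 3 and a step that the two limits leave unreadable from compound 2 to compound 3, none of which can be given a size because both ends sit at the limit. The change to a 1-methylhexyl group is larger than any of those, but nothing measured here shows what a longer chain on that nitrogen does. The step from compound 2 to compound 4 is therefore expected to be a number no higher from compound 2 to compound 4 (the limit leaves the size open), with the limit most likely reported again. Compound 4 is expected to give 125000 nM, within 40000 nM to 250000 nM.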

Compound 4, half-maximal cytotoxic concentration: > 125000 nM
Compound 4: a limit, no number; the forecaster's own chance of this, stated with the estimate: 70%; the middle value lies on the limit itself.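

In this assay, going by these compounds alone, compound 4 gives > 125000 nM as a limit and not a number, so no step among compound 1, compound 2, compound 3 and compound 4 can be read: the limit of > 125000 nM in this assay, at which 4 of the 4 values shown sit. The compounds shown leave open whether any change on that nitrogen alters the read-out.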